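The source may report more compounds than this note shows. Statements on the series, on what has been measured and on what is new or still open speak of the compounds shown alone.

Compound 3 `CC/N=c1\nc(N)c2nc[nH]c2c(N)n1` carries the core without a substituent on the ring nitrogen; in a functional assay on NCI-H460 cells (Homo sapiens) for antiproliferative activity, read by WST assay, with a stated time of 72 h (on this read-out lower numbers stand for stronger inhibition and higher numbers for weaker inhibition), compound 3 gives 22000 nM. Compound 2 `CCCCCCCC/N=c1\nc(N)c2ncn(Cc3ccccc3)c2c(N)n1` and compound 1 `CCCCCCCCCCCCCC/N=c1\nc(N)c2ncn(Cc3ccccc3)c2c(N)n1` share a different core, and the difference between the two cores is not broken down here. In this assay compound 2 gives 7450 nM and compound 1 gives 6750 nM. The change from compound 2 to compound 1 is hexyl in place of hydrogen on a saturated chain carbon, eight bonds along the chain from a double-bonded nitrogen, and it made a 1.1-fold lower number from compound 2 to compound 1 (0.04 log units; within the scatter). Compound 4 `CCCCCCCC/N=c1\nc(N)c2nc[nH]c2c(N)n1` has not yet been measured; it differs from compound 3 by hexyl in place of hydrogen on a saturated chain carbon, two bonds along the chain from a double-bonded nitrogen. This is the same kind of change, but the place is not the same: in compound 1 the hexyl enters eight bonds along the chain from a double-bonded nitrogen, whereas in compound 4 it enters two bonds along the chain from that nitrogen. From compound 3 to compound 4 the step is expected to be a 1.7-fold lower number from compound 3 to compound 4 (0.23 log units; within the scatter), resting on the chain extension from compound 2 to compound 1 having made only a 1.1-fold lower number from compound 2 to compound 1 (0.04 log units; within the scatter), and on compound 2 giving 7450 nM against compound 3 giving 22000 nM. Compound 4 is therefore estimated at 13000 nM, between 5000 nM and 32000 nM.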

Compound 4, half-maximal inhibitory concentration: "not active" (no number reported)
The entry for compound 4 holds no number; there is nothing to compare the estimate with.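

In this assay, for the compounds shown here, compound 4 is recorded as not active, without a number, so no step from compound 3 to compound 4 can be read. The compounds shown leave open how far the hexyl change moves the number on the core of compound 3. No evidence given here bears on this result.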